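A few compounds are considered here, and "the series" means these few. Any claim that something is new, unique, unknown or untested is made for them only; others in the source may bear on it.

Compounds measured so far:

Compound 1, `CCOC(=O)C1=C(Nc2ccccc2)S/C(=C\c2ccccc2)C1=O`, gives 20.3% in a functional assay on JAR cells (Homo sapiens) for inhibition, read by MTT assay, with a stated time of 72 h, tested at 10 uM; a lower number here means less inhibition, a higher number more inhibition at the concentration tested (going by the name of the read-out).
Compound 2, `CCOC(=O)C1=C(Nc2ccccc2)S/C(=C\c2ccccc2O)C1=O`, gives 89.4% in this assay.

Compound 2 stands highest of the two numbers; its nearest neighbour is compound 1, and the step of a number 69.1 percentage points higher from compound 1 to compound 2 (beyond the scatter) sets the two well apart. Compound 3, `CCOC(=O)C1=C(Nc2ccccc2)S/C(=C\c2ccccc2C(F)(F)F)C1=O`, is not yet measured. Its change from compound 2 is trifluoromethyl in place of hydroxy on an aromatic carbon. Among the compounds with values here, only one measured step bears on it: the hydroxy in place of hydrogen that gave a number 69.1 percentage points higher from compound 1 to compound 2 (beyond the scatter). Within the data shown here, compound 3 undoes that hydroxy, which on its own would point back toward the number of compound 1, while the trifluoromethyl that enters has no counterpart among the measured compounds, so its effect cannot be judged from the data. The expected step is therefore a fall, a number 54.4 percentage points lower from compound 2 to compound 3 (beyond the scatter), but with wide uncertainty. Compound 3 is estimated at 35%, in the range 10% to 75%.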

Compound 3, a percentage reported as inhibition, at one concentration (the size of the read-out at that concentration, not a potency): 29%
Estimate against measurement, compound 3: 6 percentage points above; low and high end bracket the measured number.
By their numbers in this assay, from the lowest: compounds 1 and 3 (each within the scatter of the next); then compound 2.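

On this aromatic carbon, ortho to a large group, trifluoromethyl does not take the place of hydroxy in this assay: the exchange gives a number 60.4 percentage points lower from compound 2 to compound 3 (beyond the scatter). Set against hydrogen, trifluoromethyl shows no separable difference, with a number 8.7 percentage points higher from compound 1 to compound 3 (within the scatter), so among these three compounds only the hydroxy compound stands apart at this place. Nothing available explains why the hydroxy compound stands apart.

The compounds shown leave open whether the high number belongs to hydroxy alone: a methoxy group, an amine or a carboxylic acid on the same aromatic carbon could fall with compound 2 or with compounds 1 and 3. On these data alone, whether the hydroxy step holds when other parts of the shared core change also remains open.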